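A few compounds are considered here, and "the series" means these few. Any claim that something is new, unique, unknown or untested is made for them only; others in the source may bear on it.

In a functional assay on MCF7 cells (Homo sapiens) for inhibition, read by sulforhodamine B assay, with a stated time of 48 h (on this read-out lower numbers stand for stronger inhibition of growth and higher numbers for weaker inhibition of growth), compound 1 `c1ccc2cc(NC3=NCCO3)ccc2c1` gives 4500 nM while compound 2 `c1cc(NC2=NCCO2)cc(OC2CCCCCC2)c1` gives 14800 nM in the same test. Compound 3 `O=C(CCl)NC(=O)Nc1ccc(C2CCCCC2)cc1` gives 1500 nM and so holds the lowest of the three numbers, with both others higher by more than the usual scatter. Compound 4 `O=C(CCl)NC(=O)Nc1ccc(OC2CCCC2)cc1` keeps all of compound 3 except one group, and the change is cyclopentyloxy in place of cyclohexyl on an aromatic carbon with cyclopentyloxy in place of cyclohexyl on an aromatic carbon. Going by the values given here, no two measured compounds differ in one place only, so the data hold no direct measure of such a swap, and the distant structure of compound 2 offers little guidance. Both groups carry a non-aromatic ring of carbon only and the rest of the molecule stays the same, so only a small change is expected. The expectation leans towards a higher number, given that compound 3 at 1500 nM already stands lowest among the three. The estimated move is a 1.6-fold higher number from compound 3 to compound 4 (0.20 log units; within the scatter) and would stay within the usual scatter of repeated measurements. In this assay compound 4 is estimated at 2400 nM within an expected range of 900 nM to 6000 nM until its measurement is available.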

Compound 4, concentration for 50% growth inhibition: 3900 nM
The estimate for compound 4 lay 1.6-fold (0.21 log units) below the measured number, within the range that was stated.
By their numbers in this assay, from the lowest: compound 3; then compounds 4 and 1 (each within the scatter of the next); then compound 2.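

In this assay, going by these compounds alone, the swap of cyclohexyl for cyclopentyloxy on the aromatic carbon para to a group of 8 heavy atoms gives a 2.6-fold higher number from compound 3 to compound 4 (0.41 log units; beyond the scatter) as the first direct measure of a change at this position; no earlier pair of compounds differed in one place only. The step is modest but lies beyond the scatter, so this position responds to an exchange between two groups of 6 heavy atoms, each with one non-aromatic ring of carbon only, the ring going from six-membered to five-membered and the entering group adding an oxygen and 1 hydrogen-bond acceptor. Nothing measured alongside these compounds ties the step to any one of these differences.

The compounds shown leave open whether the step follows the oxygen or the ring size, a question that cyclopentyl or cyclohexyloxy at the same place would separate. They also leave open how this position would respond to a group without a ring, such as a butoxy chain or an amine.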